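This account rests on a few compounds, and the source may have more. Where it says the series, first, only, none or still open, it means among the compounds named here.

In a functional assay on A549 cells (Homo sapiens) for cytotoxicity, read by MTT assay, with a stated time of 72 h (on this read-out lower numbers stand for stronger inhibition and higher numbers for weaker inhibition), compound 2 `Cc1cc(=O)n(-c2ccc(Br)cc2F)nc1C(=O)Nc1ccc(Oc2ncnc3sccc23)cc1` gives 12800 nM, and the only comparator, compound 1 `Cc1cc(=O)n(-c2ccccc2C(F)(F)F)nc1C(=O)Nc1ccc(Oc2ncnc3sccc23)cc1`, gives 19900 nM; the step of a 1.6-fold lower number from compound 1 to compound 2 (0.19 log units; within the scatter) separates the two. Compound 3 `Cc1cc(=O)n(-c2ccccc2OC(F)(F)F)nc1C(=O)Nc1ccc(Oc2ncnc3sccc23)cc1` differs from compound 2 by 2-(trifluoromethoxy)phenyl in place of 4-bromo-2-fluorophenyl on an aromatic nitrogen. Among the compounds with values here, the one measured step, also an exchange of the aryl group on that aromatic nitrogen, stayed within the scatter, so no step beyond the scatter is expected in this assay, and the step from compound 2 to compound 3 is estimated as a 1.2-fold higher number from compound 2 to compound 3 (0.07 log units; within the scatter). Compound 3 is therefore expected to give about 15000 nM, within a range from 6000 nM to 40000 nM.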

Compound 3, half-maximal inhibitory concentration: 15500 nM
Compound 3: the middle estimate sits 1.0-fold (0.01 log units) below what was measured, within the range that was stated.
By their numbers in this assay, from the lowest: compounds 2, 3 and 1 (each within the scatter of the next).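

In this assay the exchange of aryl groups on the aromatic nitrogen gives a 1.2-fold higher number from compound 2 to compound 3 (0.08 log units; within the scatter) and the exchange at the ortho group gives a 1.3-fold lower number from compound 1 to compound 3 (0.11 log units; within the scatter) as its result. Trifluoromethoxy and trifluoromethyl on the aromatic carbon thus give values within the scatter of each other, and a third aryl group on this nitrogen also stays within the scatter. No evidence bears on a cause for this. The compounds shown leave open whether an amine or a carboxylic acid on this phenyl ring would give a step beyond the scatter.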